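This account rests on a few compounds, and the source may have more. Where it says the series, first, only, none or still open, it means among the compounds named here.

Working notes on the series.

Compound 1 `N#Cc1c(Cl)nc(SCc2nc3ccccc3[nH]2)nc1-c1ccccc1` and compound 2 `N#Cc1c(NC(N)=S)nc(SCc2nc3ccccc3[nH]2)nc1-c1ccccc1` share a core and differ at one aromatic carbon. In a functional assay on SF-268 cells (Homo sapiens) for cytotoxicity, read by MTT assay, with a stated time of 3 days (a higher number here means a weaker inhibitor, a lower number a stronger inhibitor), compound 1 gives 3.2 nM, and compound 2 gives 3.37 nM in this assay; the two numbers lie within the scatter of each other, so neither can be set above the other. Among the measured compounds shown here, the one step measured so far, a 1.1-fold higher number from compound 1 to compound 2 (0.02 log units; within the scatter), put a group of 4 heavy atoms (1 carbon, 2 nitrogen, 1 sulfur; no ring) in place of one chlorine atom, on an aromatic carbon, and left the number essentially unchanged.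

Compound 3 `CN1CCN(c2nc(SCc3nc4ccccc4[nH]3)nc(-c3ccccc3)c2C#N)CC1` takes the same position further: a group of 7 heavy atoms (5 carbon, 2 nitrogen; one six-membered non-aromatic ring with 2 hetero atoms) in place of a group of 4 heavy atoms (1 carbon, 2 nitrogen, 1 sulfur; no ring), on an aromatic carbon. For the measured compounds named here, the group that leaves is the one that entered in the single measured step; the group that enters, 4-methylpiperazin-1-yl, is larger and ring-bearing, and no measured step tests a group of that kind at this position. Going by the values given here, since the only comparison at this carbon, that from compound 1 to compound 2, stayed within the scatter, a small step is expected for compound 3, a 1.5-fold higher number from compound 2 to compound 3 (0.17 log units; within the scatter), with the wider range reflecting the lack of a closer precedent. Compound 3 is estimated at 5 nM in this assay, between 1.5 nM and 20 nM.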

Compound 3, half-maximal inhibitory concentration: 6.9 nM
Beside the measured number, compound 3's estimate is 1.4-fold (0.14 log units) below it, within the range that was stated.
By their numbers in this assay, from the lowest: compounds 1 and 2 (each within the scatter of the next); then compound 3.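

Among the compounds shown here, at the aromatic carbon ortho to a cyano group, the first change to go beyond the scatter in this assay is the move to 4-methylpiperazin-1-yl, with a 2.0-fold higher number from compound 2 to compound 3 (0.31 log units; beyond the scatter) as the ring-bearing group replaces the acyclic group of compound 2. The comparison with the chloro group points the same way, with a 2.2-fold higher number from compound 1 to compound 3 (0.33 log units; beyond the scatter) and both steps classed as modest. This carbon therefore responds to the group it carries, though only modestly: the larger group with one six-membered non-aromatic ring moves the number upward, towards weaker inhibition, by a small margin, while the earlier exchange of chloro for the acyclic group stayed within the scatter.

Still open is whether the upward shift belongs to the ring, to its size or to the methyl group on it; morpholine, piperazine without the methyl group and an open-chain amine such as dimethylamino would each separate these readings at this carbon, and the phenyl group and the benzimidazole-bearing thioether side of the core remain untested by any step shown here. No supporting measurement is available to explain the shift.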